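Swapping the sulfonyl aryl group in a squalene monooxygenase series

The source may report more compounds than this note shows. Statements on the series, on what has been measured and on what is new or still open speak of the compounds shown alone.

Of the compounds shown here, three that share one core have been tested in a functional assay on HepG2 cells for inhibition of squalene monooxygenase (Homo sapiens); on this read-out higher numbers stand for weaker inhibition and lower numbers for stronger inhibition. Compound 1 `CCN(C/C=C/C#CC(C)(C)C)Cc1cccc(OCCN(C)S(=O)(=O)c2ccc(Br)cc2)c1` gives 330 nM. Compound 2 `CCN(C/C=C/C#CC(C)(C)C)Cc1cccc(OCCN(C)S(=O)(=O)c2cccnc2)c1` gives 150 nM, and compound 3 `CCN(C/C=C/C#CC(C)(C)C)Cc1cccc(OCCN(C)S(=O)(=O)Cc2cccs2)c1` gives 200 nM. Compound 3 has the second highest of the three numbers; the nearest of the other two is compound 2 and the furthest is compound 1. The two steps concerned are a 1.3-fold higher number from compound 2 to compound 3 (0.12 log units; within the scatter) and a 1.7-fold lower number from compound 1 to compound 3 (0.22 log units; within the scatter), so neither of these two differences can be told from repeat noise. Among the measured compounds shown here, the only step that is beyond the scatter is a 2.2-fold lower number from compound 1 to compound 2 (0.34 log units; beyond the scatter).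

Compound 4 `CCN(C/C=C/C#CC(C)(C)C)Cc1cccc(OCCN(C)S(=O)(=O)c2cc3ccccc3s2)c1` carries 1-benzothiophen-2-yl in place of (thiophen-2-yl)methyl on a sulfonyl sulfur. For the measured compounds named here, the steps that bear on it are the ones that also change the group on the sulfonyl sulfur, namely a 1.7-fold lower number from compound 1 to compound 3 (0.22 log units; within the scatter) and a 1.3-fold higher number from compound 2 to compound 3 (0.12 log units; within the scatter), both within the scatter, and a 2.2-fold lower number from compound 1 to compound 2 (0.34 log units; beyond the scatter), which is modest. Going by the values given here, no measured step puts a fused two-ring group at this position, so nothing here argues for a large move in either direction. For compound 4 the expected step is therefore no change at the digits printed from compound 3 to compound 4 (within the scatter), nothing beyond the scatter, and the estimate for compound 4 in this assay is 200 nM, with a range from 80 nM to 500 nM.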

Compound 4, half-maximal inhibitory concentration: 1800 nM
Compound 4: the middle estimate sits 9.0-fold (0.95 log units) below what was measured; the measured number lies above the stated range.
By their numbers in this assay, from the lowest: compounds 2, 3 and 1 (each within the scatter of the next, the first and the last beyond it); then compound 4.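

In this assay, the group on the sulfonyl sulfur proves able to move the number much further than the first three compounds suggested: 1-benzothiophen-2-yl in place of (thiophen-2-yl)methyl gives a 9.0-fold higher number from compound 3 to compound 4 (0.95 log units; beyond the scatter) and the same group gives a 12-fold higher number from compound 2 to compound 4 (1.08 log units; beyond the scatter) and also a 5.5-fold higher number from compound 1 to compound 4 (0.74 log units; beyond the scatter) in the comparison with 4-bromophenyl. Compound 4 is therefore the weakest of the four inhibitors, and this position does not accept every aromatic group equally, although the three earlier groups stay much closer together. The data offer no measured explanation for this loss of inhibition.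

The step from (thiophen-2-yl)methyl to 1-benzothiophen-2-yl both adds a six-membered aromatic ring of carbon only and removes the methyl link, so the compounds shown cannot say which of these two changes matters. A plain thiophen-2-yl group on the sulfonyl sulfur would test the loss of the link alone, while a (1-benzothiophen-2-yl)methyl group would test the added ring alone.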